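Swapping an Amide Tail for a Chlorophenoxy Ether

The source may report more compounds than this note shows. Statements on the series, on what has been measured and on what is new or still open speak of the compounds shown alone.

Of the compounds shown here, three sharing one core have been tested in a functional assay on PANC-1 cells (Homo sapiens) for inhibition, read by MTT assay, with a stated time of 24 h, tested at 10 uM; on this read-out lower numbers stand for less inhibition and higher numbers for more inhibition at the one concentration tested (going by the name of the read-out). Compound 1 `CC(C)=CCC1Cc2c(OCCCNS(=O)(=O)c3ccc(Br)cc3)cc(=O)n(CCCO)c2CC1(C)C` gives 3.7%, compound 2 `COc1ccc(C(=O)NCCCOc2cc(=O)n(CCCO)c3c2CC(CC=C(C)C)C(C)(C)C3)cc1` gives 2.5%, and compound 3 `CC(C)=CCC1Cc2c(OCCCNC(=O)c3ccc([N+](=O)[O-])cc3)cc(=O)n(CCCO)c2CC1(C)C` gives 9.1%. Compound 3 holds the highest of the three numbers, yet the steps of a number 5.4 percentage points higher from compound 1 to compound 3 (within the scatter) and a number 6.6 percentage points higher from compound 2 to compound 3 (within the scatter) both fall within the scatter, so the three cannot be told apart. Compound 4 `CC(C)=CCC1Cc2c(OCCCOc3ccc(Cl)cc3)cc(=O)n(CCCO)c2CC1(C)C` differs from compound 3 in one place: 4-chlorophenoxy in place of ((4-nitrophenyl)carbonyl)amino on a saturated chain carbon, three bonds along the chain from an oxygen on an aromatic ring. For the measured compounds named here, no measured step removes the amine nitrogen; the nearest comparisons, a number 1.2 percentage points lower from compound 1 to compound 2 (within the scatter) and a number 5.4 percentage points higher from compound 1 to compound 3 (within the scatter), were small. Since every change so far stayed within the scatter, compound 4 is expected to stay low, a step of a number 3.1 percentage points lower from compound 3 to compound 4 (within the scatter). Compound 4 is estimated at 6%, ranging from 0% to 16%.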

Compound 4, a percentage reported as inhibition, at one concentration (the size of the read-out at that concentration, not a potency): 0%
Compound 4: middle estimate off by 6 percentage points, on the high side; measured number inside the range.
By their numbers in this assay, from the lowest: compounds 4, 2, 1 and 3 (each within the scatter of the next).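

Replacing the amide or sulfonyl tail with 4-chlorophenoxy removes the amine nitrogen from the chain, yet all three steps in this assay stay within the scatter: a number 9.1 percentage points lower from compound 3 to compound 4 (within the scatter), a number 2.5 percentage points lower from compound 2 to compound 4 (within the scatter) and a number 3.7 percentage points lower from compound 1 to compound 4 (within the scatter). This position therefore gives the same reading, within the scatter, with or without that nitrogen and its hydrogen-bond donor. No measurement is available that would explain this result. On these data alone, whether any group here can give a reading beyond the scatter remains open, for example a free amine or a carboxylic acid at the end of the chain, or a longer chain.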